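Swapping a Benzylamide for a Dipropylamide

The compounds below may be only part of what the source reports. "The series", "measured", "known", "first", "only" and "open" are said of these compounds alone.

Measured in a functional assay on HL-60 cells (Homo sapiens), with a stated time of 4 days; on this read-out higher numbers stand for weaker inhibition and lower numbers for stronger inhibition:
- compound 1 `Cc1ccc(CNC(=O)c2[nH]cnc2C(=O)Nc2ccc(Cl)c(Cl)c2)cc1` gives 15200 nM
- compound 2 `COc1ccc(CNC(=O)c2[nH]cnc2C(=O)Nc2ccc(Cl)c(Cl)c2)cc1` gives 18300 nM

Compound 1 has the lowest number of the two, yet the gap to compound 2, the change a 1.2-fold higher number from compound 1 to compound 2 (0.08 log units; within the scatter), is within the scatter, so the two cannot be told apart on this read-out. Both are weak inhibitors.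

Compound 3 `CCCN(CCC)C(=O)c1[nH]cnc1C(=O)Nc1ccc(Cl)c(Cl)c1` differs from compound 1 in one place: dipropylamino in place of (4-methylbenzyl)amino on a carbonyl carbon. Going by the values given here, the only measured step, from compound 1 to compound 2, concerns a substituent on the aromatic ring that leaves here and says nothing about replacing the whole (4-methylbenzyl)amino group with dipropylamino. Among the compounds with values here, there is therefore no measured step that bears on this change, and no direction can be read from the data.

Compound 3 is expected to sit near compound 1, with the step of a 1.3-fold higher number from compound 1 to compound 3 (0.12 log units; within the scatter) as a placeholder rather than a prediction, and a wide range. The estimate for compound 3 in this assay is 20000 nM, between 5000 nM and 80000 nM.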

Compound 3, half-maximal inhibitory concentration: 38900 nM
Compound 3: the middle estimate sits 1.9-fold (0.29 log units) below what was measured, and the stated range covers the measured number.
By their numbers in this assay, from the lowest: compounds 1 and 2 (each within the scatter of the next); then compound 3.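

In this assay, going by these compounds alone, the step of a 2.6-fold higher number from compound 1 to compound 3 (0.41 log units; beyond the scatter) is the first to lie beyond the scatter, so this position responds when the whole group on the carbonyl carbon is replaced, whereas the earlier change on the aromatic ring gave no readable difference. Since a higher number means weaker inhibition, putting dipropylamino in place of (4-methylbenzyl)amino weakens inhibition modestly, and compound 3 still gives a finite number in a series that was weak to begin with. Nothing at hand explains why the number rises.

The change removes the aromatic ring and the hydrogen-bond donor together, so these compounds cannot show which of the two matters, or whether the overall shape of the group matters instead. As far as these compounds go, a propylamino group would keep the amide hydrogen without the ring, and a benzyl(propyl)amino group would keep the ring without that hydrogen, so either could help separate the two, and where each would fall relative to compound 1 and compound 3 remains open.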